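Imidazolyl variation on the diphenylpropanamide series

This account rests on a few compounds, and the source may have more. Where it says the series, first, only, none or still open, it means among the compounds named here.

Compound 2 `CC(C)(C)c1nccn1CCC(C(N)=O)(c1ccccc1)c1ccccc1` gives 30.2 nM in an assay on ileum with muscarinic acetylcholine receptor M3 (Cavia porcellus) as the target (on this read-out lower numbers stand for stronger inhibition and higher numbers for weaker inhibition), the second highest of the three numbers; compound 1 `CC(C)c1nccn1CCC(C(N)=O)(c1ccccc1)c1ccccc1` gives 1.8 nM and compound 3 `CCCc1ncn(CCC(C(N)=O)(c2ccccc2)c2ccccc2)c1CCC` gives 100 nM. Compound 4 `Cc1cncn1CCC(C(N)=O)(c1ccccc1)c1ccccc1` carries the change (5-methyl-1H-imidazol-1-yl in place of 2-(tert-butyl)-1H-imidazol-1-yl on a saturated chain carbon, three bonds along the chain from two aromatic carbons and a carbonyl carbon). Among the compounds with values here, the only step that bears on it is a 17-fold higher number from compound 1 to compound 2 (1.22 log units; beyond the scatter): a single extra methyl at the 2-substituent of the imidazole brought a large loss. Within the data shown here, compound 4 removes that substituent altogether and instead carries a methyl at the 5-position, a change no measured pair covers directly. Since the smaller 2-substituent of compound 1 gave 1.8 nM, a move back toward that level seems more likely than a further loss, so compound 4 is expected at about 5 nM (range 1 nM to 30 nM), a step of a 6.0-fold lower number from compound 2 to compound 4 (0.78 log units; beyond the scatter), with the uncertainty wide.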

Compound 4, antagonist equilibrium constant: 0.86 nM
Compound 4: middle estimate off by 5.8-fold (0.76 log units), on the high side; measured number below the stated range.
By their numbers in this assay, from the lowest: compound 4; then compound 1; then compound 2; then compound 3.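

In this assay, 5-methyl-1H-imidazol-1-yl in place of 2-(tert-butyl)-1H-imidazol-1-yl gives a 35-fold lower number from compound 2 to compound 4 (1.55 log units; beyond the scatter), so a low number at this place on the chain does not depend on a 2-alkyl group. Against 2-isopropyl-1H-imidazol-1-yl, the same group gives a modest step, a 2.1-fold lower number from compound 1 to compound 4 (0.32 log units; beyond the scatter). No available evidence accounts for either step. From the compounds shown here alone, what the methyl itself contributes remains open. Unsubstituted 1H-imidazol-1-yl, or an ethyl or trifluoromethyl group in place of that methyl, would separate its contribution from that of the imidazole.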